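Swapping benzofuran for pyridine in a urotensin ligand

The source may hold more compounds than are shown below. What is called first, only, known or untested is meant among the compounds shown, and "the series" means these compounds.

Among the compounds with values here, compound 2 `CC(C)C[C@H](NC(=O)c1cc2ccccc2o1)C(=O)N[C@H]1CCN(Cc2ccc(OCCCN(C)C)cc2)C1` is the only member of this set with a number in an assay on HEK293 cells for binding affinity to Urotensin-2 receptor (Homo sapiens), read by radioligand binding (on this read-out higher numbers stand for weaker inhibition and lower numbers for stronger inhibition), where compound 2 gives 158 nM. Compound 1 `CN(C)CCCOc1ccc(CN2CC[C@H](NC(=O)c3ccc4ccccc4c3)C2)cc1` reaches only a limit of this assay, < 10000 nM. Compound 3 `CC(C)C[C@H](NC(=O)c1cc2ccccc2o1)C(=O)N[C@@H]1CCN(Cc2ccc(OCCCN(C)C)cc2)C1` likewise gives only a limit, < 10000 nM. Within the data shown here, the sole step between measured compounds, a step that the limit leaves unreadable from compound 2 to compound 3, cannot be sized because of the limit of < 10000 nM in this assay, at which 2 of the 3 values shown sit; it concerns configuration, since (the fact that compounds 2 and 3 differ only in the configuration as drawn), and says nothing about a change of the aromatic group. Compound 4 `CC(C)C[C@H](NC(=O)c1ccncc1)C(=O)N[C@H]1CCN(Cc2ccc(OCCCN(C)C)cc2)C1` differs from compound 2 by pyridin-4-yl in place of 1-benzofuran-2-yl on a carbonyl carbon. Among the measured compounds shown here, no measured step covers this kind of exchange, so the expectation rests on compound 2 alone and is wide. Compound 4 is expected to give 800 nM, between 150 nM and 5000 nM, so the estimated step of a 5.1-fold higher number from compound 2 to compound 4 (0.70 log units; beyond the scatter) leans toward weaker binding.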

Compound 4, inhibition constant: 2000 nM
The estimate for compound 4 lay 2.5-fold (0.40 log units) below the measured number; the range from low to high includes it.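

In this assay, within the data shown here, the exchange on the carbonyl carbon gives a 13-fold higher number from compound 2 to compound 4 (1.10 log units; beyond the scatter), the first change of the aromatic group here that can be read as a number, and it is large. Compound 4 still gives a number, 2000 nM, with one aromatic ring in place of two, so binding in this series does not rest wholly on 1-benzofuran-2-yl. Nothing shown gives a cause for this step. Going by these compounds, it stays open whether the step follows the ring nitrogen or the loss of the second ring. A phenyl or a quinolin-2-yl group on the same carbonyl would separate the two.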